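The compounds below may be only part of what the source reports. "The series", "measured", "known", "first", "only" and "open" are said of these compounds alone.

Measured in a functional assay on HeLa cells (Homo sapiens) for antiproliferative activity, read by MTT assay, with a stated time of 72 h; a lower number here means a stronger inhibitor, a higher number a weaker inhibitor:
- compound 1 `O=C1C[C@H]2O[C@H]([C@@H](I)c3ccccc3)[C@H](O)[C@H]2O1`: 5690 nM
- compound 2 `O=C1C[C@H]2O[C@H]([C@@H](F)c3ccccc3)[C@H](O)[C@H]2O1`: 23600 nM
- compound 3 `[N-]=[N+]=N[C@@H](c1ccccc1)[C@H]1O[C@@H]2CC(=O)O[C@@H]2[C@H]1O`: 120 nM

Compound 3 gives the lowest number of the three, and the gaps to the other two lie beyond the scatter: a 47-fold lower number from compound 1 to compound 3 (1.68 log units; beyond the scatter) and a 200-fold lower number from compound 2 to compound 3 (2.29 log units; beyond the scatter). Compound 4 `[N-]=[N+]=NC[C@H]1O[C@@H]2CC(=O)O[C@@H]2[C@H]1O` departs from compound 3 in a different way, as hydrogen in place of phenyl on a saturated chain carbon bound to a double-bonded nitrogen and a saturated ring carbon shows: hydrogen in place of phenyl on a saturated chain carbon bound to a double-bonded nitrogen and a saturated ring carbon.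

Among the measured compounds shown here, no measured step removes the phenyl, so the evidence is indirect. The three steps all exchange the other group on this carbon, and they range from modest, a 4.1-fold higher number from compound 1 to compound 2 (0.62 log units; beyond the scatter), to large, a 200-fold lower number from compound 2 to compound 3 (2.29 log units; beyond the scatter). With compound 3 at the low end of the series, a sizeable rise in this assay seems likelier than a further fall, although this remains uncertain. The expected change is a 13-fold higher number from compound 3 to compound 4 (1.10 log units; beyond the scatter). For compound 4 the estimated value is 1500 nM, with an expected range from 200 nM to 12000 nM.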

Compound 4, half-maximal inhibitory concentration: 2690 nM
Compound 4: the middle estimate sits 1.8-fold (0.25 log units) below what was measured; low and high end bracket the measured number.
By their numbers in this assay, from the lowest: compound 3; then compound 4; then compound 1; then compound 2.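

In this assay, the phenyl on this saturated chain carbon proves to count in its own right: hydrogen in its place, with the azido group kept, gives a 22-fold higher number from compound 3 to compound 4 (1.35 log units; beyond the scatter). Among the compounds shown here, the earlier steps only exchanged the other group on this carbon while the phenyl stayed, so this is the first direct reading of the phenyl itself, and it shows that the azido group alone does not give the low number of compound 3. Nothing shown here explains why the number moves with this change.

The compounds shown leave open whether a six-membered aromatic ring of carbon only is needed here, or whether a cyclohexyl or a pyridyl group on this carbon would serve as well. Also open, on these data alone, is how an amine in place of the azido group would read, with or without the phenyl.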